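Compound 4: Swapping the Amide Substituent of Compound 3

The source may report more compounds than this note shows. Statements on the series, on what has been measured and on what is new or still open speak of the compounds shown alone.

Compound 1 `CCn1c(C(=O)N[C@@H](C)CO)ccc1C(CC)(CC)c1ccc(OCS(=O)(=O)c2ccccc2)c(C)c1` – 10800 nM
Compound 2 `CCn1c(C(=O)NC(C)(C)CO)ccc1C(CC)(CC)c1ccc(OCS(=O)(=O)c2ccccc2)c(C)c1` – 20700 nM
Compound 3 `CCn1c(C(=O)N[C@H](CO)CCCO)ccc1C(CC)(CC)c1ccc(OCS(=O)(=O)c2ccccc2)c(C)c1` – 31400 nM

These values come from a functional assay on MCF7 cells (Homo sapiens) for antiproliferative activity, read by MTT assay, with a stated time of 24 h; a lower number here means a stronger inhibitor, a higher number a weaker inhibitor. Compound 3 sits with compound 2 at the upper end of the three numbers. The data show a 1.5-fold higher number from compound 2 to compound 3 (0.18 log units; within the scatter), and also a 2.9-fold higher number from compound 1 to compound 3 (0.46 log units; beyond the scatter).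

Compound 4 `CCn1c(C(=O)N[C@H](C)C(=O)O)ccc1C(CC)(CC)c1ccc(OCS(=O)(=O)c2ccccc2)c(C)c1` keeps the core of compound 3 and alters only the group on an amide-type nitrogen: a group of 5 heavy atoms (3 carbon, 2 oxygen; no ring) in place of a group of 7 heavy atoms (5 carbon, 2 oxygen; no ring), on an amide-type nitrogen. For the measured compounds named here, the group that enters is 1-carboxyethyl, which no measured compound carries, so the evidence is indirect. All three measured steps fall on this same nitrogen, and they stay small: a 1.9-fold higher number from compound 1 to compound 2 (0.28 log units; within the scatter) is within the scatter, and the largest, the step to compound 3 from compound 1, is modest. A step beyond the scatter in either direction is therefore not expected.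

The expected result is a 1.3-fold lower number from compound 3 to compound 4 (0.10 log units; within the scatter).

Compound 4 is estimated at 25000 nM, with an expected range from 8000 nM to 70000 nM.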

Compound 4, half-maximal inhibitory concentration: > 50000 nM
Compound 4: only a limit was reported (the forecaster's own chance of this, stated with the estimate: 20%); middle value at least 2.0-fold (0.30 log units) from the limit.
By their numbers in this assay, from the lowest: compounds 1, 2 and 3 (each within the scatter of the next, the first and the last beyond it). At a limit, above all of these: compound 4.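

In this assay, compound 4, with 1-carboxyethyl on the amide-type nitrogen, gave no number but only a limit: the limit of > 50000 nM in this assay, at which 1 of the 4 values shown sits.

Set against 1-(hydroxymethyl)-1-methylethyl and 1-(hydroxymethyl)ethyl, the change reads as an at least 2.4-fold higher number from compound 2 to compound 4 (0.38 log units; beyond the scatter) and an at least 4.6-fold higher number from compound 1 to compound 4 (0.66 log units; beyond the scatter), so 1-carboxyethyl is the first group here whose floor alone puts it beyond the scatter of compound 2, the neighbour nearest in value among those two. Against compound 3 the reading is an at least 1.5-fold higher number from compound 3 to compound 4 (0.20 log units; that floor lies within the scatter), and that floor does not separate the two compounds.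

From the compounds shown here alone, how far compound 4 lies past its limit remains unknown. The compounds shown also cannot tell whether the same shift would follow from a methyl ester or a primary amide in place of the carboxylic acid, or from a longer chain carrying that acid.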